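Chloro on the anilide ring: compound 2 to compound 3

The source may hold more compounds than are shown below. What is called first, only, known or untested is meant among the compounds shown, and "the series" means these compounds.

Compound 2 `CCOC(=O)c1c(NC(=O)CC#N)sc(C(=O)Nc2ccccc2)c1-c1ccccc1` holds the lowest of the two numbers recorded in a functional assay on NCI-H460 cells (Homo sapiens) for inhibition, read by MTT assay (on this read-out lower numbers stand for stronger inhibition and higher numbers for weaker inhibition), where compound 2 gives 490 nM. Within the data shown here, its only neighbour is compound 1 `CCOC(=O)c1c(N)sc(C(=O)Nc2ccccc2)c1-c1ccccc1`, which in this assay gives 8590 nM; the single measured step, an 18-fold lower number from compound 1 to compound 2 (1.24 log units; beyond the scatter), came with (cyanomethyl)carbonyl in place of hydrogen on a nitrogen on an aromatic ring. Compound 3 `CCOC(=O)c1c(NC(=O)CC#N)sc(C(=O)Nc2ccc(Cl)cc2)c1-c1ccccc1` differs from compound 2 by chloro in place of hydrogen on an aromatic carbon, so the phenylcarbamoyl becomes (4-chlorophenyl)carbamoyl while the rest of the shared core is unchanged. Among the measured compounds shown here, no measured step touches this six-membered aromatic ring of carbon only; the one step known concerns a different part of the molecule, and its size carries nothing over to the present change. The expectation for compound 3 in this assay is therefore a step no larger than the scatter, a 1.2-fold lower number from compound 2 to compound 3 (0.07 log units; within the scatter). Compound 3 is estimated at 420 nM in this assay, within a range of 150 nM to 1200 nM.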

Compound 3, half-maximal inhibitory concentration: 430 nM
The estimate for compound 3 lay 1.0-fold (0.01 log units) below the measured number; measured number inside the range.
By their numbers in this assay, from the lowest: compounds 3 and 2 (each within the scatter of the next); then compound 1.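

In this assay the chloro substitution gives a 1.1-fold lower number from compound 2 to compound 3 (0.06 log units; within the scatter), so compound 2 and compound 3 cannot be told apart on this read-out. Among these compounds, this is the first information on the six-membered aromatic ring of carbon only, as the earlier step, an 18-fold lower number from compound 1 to compound 2 (1.24 log units; beyond the scatter), concerned the nitrogen substituent: the place para to a large group accepts chloro in place of hydrogen with no step beyond the scatter. No measurement at hand offers an explanation for this result.

On these data alone, one substituent at one place says little about the ring as a whole: whether a methoxy, a trifluoromethyl or a dimethylamino group would behave like chloro remains open. Also open, as far as these compounds go, is how chloro would read on another carbon of this ring.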